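This account rests on a few compounds, and the source may have more. Where it says the series, first, only, none or still open, it means among the compounds named here.

Compound 1 `Nc1nc2cc(Cl)c(Cl)cc2n1Cc1ccccc1` is the starting point in a functional assay on KB cells (Homo sapiens) for inhibition (a lower number here means a stronger inhibitor, a higher number a weaker inhibitor), where compound 1 gives 170000 nM. Compound 2 `Cc1ccc(Cn2c(N)nc3cc(Cl)c(Cl)cc32)cc1` differs from it only by one change, (methyl in place of hydrogen on an aromatic carbon). In this assay compound 2 gives 50000 nM, which is a 3.4-fold lower number from compound 1 to compound 2 (0.53 log units; beyond the scatter). Compound 3 `Clc1cc2nc(Cl)n(Cc3ccccc3)c2cc1Cl` differs from compound 1 in the core, and that difference is chloro in place of amino on an aromatic carbon. In this assay compound 3 gives only a limit, > 100000 nM. The size of the step from compound 1 to compound 3 is therefore a step that the limit leaves unreadable from compound 1 to compound 3, because of the limit of > 100000 nM in this assay, at which 1 of the 3 values shown sits.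

Compound 4 `Cc1cccc(Cn2c(Cl)nc3cc(Cl)c(Cl)cc32)c1` has not yet been measured in this assay. It stands to compound 3 as compound 2 stands to compound 1: the change is methyl in place of hydrogen on an aromatic carbon. The two places are not described in the same words, since in compound 2 the methyl sits para to a large group and in compound 4 it sits meta to a large group, so this is the same kind of change, not the same change. The one time the methyl was measured, from compound 1 to compound 2, it gave a modest gain. Compound 3 itself stands only at a limit, so the starting value for compound 4 is not known. The step from compound 3 to compound 4 is expected to be a step that the limit leaves unreadable from compound 3 to compound 4. Compound 4 is therefore estimated at 120000 nM, expected to lie between 40000 nM and 400000 nM, with a real chance that this assay again reports only a limit for compound 4.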

Compound 4, half-maximal inhibitory concentration: > 100000 nM
Compound 4: a limit, no number (the forecaster's own chance of this, stated with the estimate: 55%); the middle value does not contradict the limit.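

The step from compound 3 to compound 4 cannot be read in this assay, because both compounds stand only at a limit: the limit of > 100000 nM in this assay, at which 2 of the 4 values shown sit.

The compounds shown leave open whether methyl in place of hydrogen on an aromatic carbon changes the number at all in compounds carrying chloro in place of amino, as it did between compound 1 and compound 2.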